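Benzothiazole Replaces Imidazole on the Thioether Link

The source may report more compounds than this note shows. Statements on the series, on what has been measured and on what is new or still open speak of the compounds shown alone.

Among the compounds with values here, compound 2 `CCOc1cc2ncnc(Nc3ccc(F)c(Cl)c3)c2cc1OC(=O)CSc1nccn1C` stands highest of the two numbers so far in a functional assay on NCI-H1975 cells (Homo sapiens) for inhibition, read by MTT assay, with a stated time of 72 h (on this read-out lower numbers stand for stronger inhibition and higher numbers for weaker inhibition), where compound 2 gives 6900 nM. Within the data shown here, its nearest neighbour is compound 1 `CCOc1cc2ncnc(Nc3ccc(F)c(Cl)c3)c2cc1OC(=O)CSc1nnnn1C`, which in this assay gives 2100 nM; the only step between measured compounds, a 3.3-fold higher number from compound 1 to compound 2 (0.52 log units; beyond the scatter), came with 1-methyl-1H-imidazol-2-yl in place of 1-methyl-1H-tetrazol-5-yl on a sulfur. Compound 3 `CCOc1cc2ncnc(Nc3ccc(F)c(Cl)c3)c2cc1OC(=O)CSc1nc2ccccc2s1` carries the change (1,3-benzothiazol-2-yl in place of 1-methyl-1H-imidazol-2-yl on a sulfur). No measured step shows this exchange; the one step shown concerns a different five-membered ring at the same sulfur, so the direction for compound 3 is uncertain. Since exchanging one small ring for another moved the number by a 3.3-fold higher number from compound 1 to compound 2 (0.52 log units; beyond the scatter), a step of comparable size in either direction, or none beyond the scatter, is expected for compound 3 in this assay. The estimate for compound 3 is 5000 nM, with a range from 1500 nM to 16000 nM, which corresponds to an expected step of a 1.4-fold lower number from compound 2 to compound 3 (0.14 log units; within the scatter).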

Compound 3, half-maximal inhibitory concentration: 9800 nM
Estimate against measurement, compound 3: 2.0-fold (0.29 log units) below, and the stated range covers the measured number.
By their numbers in this assay, from the lowest: compound 1; then compounds 2 and 3 (each within the scatter of the next).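

In this assay, adding a six-membered aromatic ring of carbon only, as 1,3-benzothiazol-2-yl replaces 1-methyl-1H-imidazol-2-yl on the sulfur, gives a 1.4-fold higher number from compound 2 to compound 3 (0.15 log units; within the scatter) and so does not separate the two compounds. Against 1-methyl-1H-tetrazol-5-yl the same group gives a 4.7-fold higher number from compound 1 to compound 3 (0.67 log units; beyond the scatter) and this leaves compound 1, with steps beyond the scatter to both others, as the most potent of the three. Nothing at hand explains this ranking of the groups on the sulfur.

As far as these compounds go, it remains open whether the lower number of compound 1 belongs to the tetrazole alone or would also appear with another nitrogen-rich ring such as a 1,2,4-triazole. From the compounds shown here alone, how a longer chain ending in an amine or a carboxylic acid would compare on that sulfur also stays unknown.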